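Replacing the azido chain end in a hydroxamate sulfonamide

The compounds below may be only part of what the source reports. "The series", "measured", "known", "first", "only" and "open" are said of these compounds alone.

In an assay on isolated protein for inhibition of matrix metalloproteinase-9 (Homo sapiens), read by fluorescence, with a stated time of 30 min (a lower number here means a stronger inhibitor, a higher number a weaker inhibitor), compound 1 `COc1ccc(S(=O)(=O)N(CCN=[N+]=[N-])[C@@H](C(=O)NO)C(C)C)cc1` gives 6 nM, the highest of the three numbers recorded. Compound 2 `Cc1ccc(S(=O)(=O)N(CCN=[N+]=[N-])[C@@H](C(=O)NO)C(C)C)cc1` gives 4 nM, and compound 3 `CC(C)[C@H](C(=O)NO)N(CCN=[N+]=[N-])S(=O)(=O)c1ccc(OCCF)cc1` gives 4 nM. Neither step moved beyond the scatter: a 1.5-fold lower number from compound 1 to compound 2 (0.18 log units; within the scatter) and a 1.5-fold lower number from compound 1 to compound 3 (0.18 log units; within the scatter). Compound 4 `COc1ccc(S(=O)(=O)N(CCn2cc(CCCF)nn2)[C@@H](C(=O)NO)C(C)C)cc1` alters a different part of the shared core: a group of 9 heavy atoms (5 carbon, 3 nitrogen, 1 fluorine; one five-membered aromatic ring with 3 hetero atoms) in place of a group of 3 heavy atoms (3 nitrogen; no ring), on a saturated chain carbon, two bonds along the chain from a sulfonamide nitrogen. Within the data shown here, none of the measured steps involves the azido group; the two steps that were measured alter the aromatic ring and were both within the scatter, so they offer no direct guide. With nothing to indicate a large effect, compound 4 is expected to stay close to compound 1, with a step of a 1.3-fold higher number from compound 1 to compound 4 (0.12 log units; within the scatter) in this assay. The estimate for compound 4 is 8 nM, between 3 nM and 25 nM.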

Compound 4, half-maximal inhibitory concentration: 0.07 nM
Estimate against measurement, compound 4: 110-fold (2.06 log units) above; the whole stated range lies above it.
By their numbers in this assay, from the lowest: compound 4; then compounds 2, 3 and 1 (each within the scatter of the next).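

In this assay, the chain end proved far more responsive than the aromatic ring: replacing azido with the group bearing one five-membered aromatic ring with 3 hetero atoms gives an 86-fold lower number from compound 1 to compound 4 (1.93 log units; beyond the scatter) while both steps measured from compound 1 on the aromatic ring stayed within the scatter. The position therefore accepts a much larger group than azido without any loss in this assay. Nothing available explains the gain.

The entering group adds a ring and a fluorinated chain together, so the compounds shown cannot separate their contributions. From the compounds shown here alone, a plain propyl chain or a hydroxyl in place of the fluorine on that ring remains open.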